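The compounds below may be only part of what the source reports. "The series", "measured", "known", "first", "only" and "open" are said of these compounds alone.

In an ADME assay on liver (Mus musculus) for metabolic stability, read by LC-MS, using microsomes and NADPH (on this read-out lower numbers stand for a less stable compound and higher numbers for a more stable compound), compound 1 `CCN(Cc1ccc(OCCn2c(=O)ccn(C)c2=O)c(C)c1)C(CC(=O)O)c1ccc(Cl)cc1` gives 37%, while compound 2 `COc1cc(CN(CC(C)C)C(CC(=O)O)c2ccc3c(c2)CCO3)ccc1OCCN1C(=O)CCC1=O` gives 100%, the higher of the two numbers and beyond the scatter from compound 1. Compound 3 `COc1cc(CN(CC(C)C)C(CC(=O)O)c2ccc(Cl)c(F)c2)ccc1OCCN1C(=O)CCC1=O` differs from compound 2 in one place: a group of 8 heavy atoms (6 carbon, 1 fluorine, 1 chlorine; one six-membered aromatic ring of carbon only) in place of a group of 9 heavy atoms (8 carbon, 1 oxygen; one five-membered non-aromatic ring with 1 hetero atom, one six-membered aromatic ring of carbon only), on a saturated chain carbon bound to an amine nitrogen and a saturated chain carbon. The 4-chloro-3-fluorophenyl group enters on a saturated chain carbon bound to an amine nitrogen and a saturated chain carbon. Among the measured compounds shown here, no measured pair isolates this change, so a moderate fall beyond the scatter is only an expectation, with compound 1 at 37% as the lower reference. The expected step is a number 30 percentage points lower from compound 2 to compound 3 (beyond the scatter). For compound 3 the estimate is 70%, with an expected range of 40% to 100%.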

Compound 3, percent of the compound remaining in the Mus musculus assay: 57%
Beside the measured number, compound 3's estimate is 13 percentage points above it; the measured number falls inside the stated range.
By their numbers in the Mus musculus assay, from the lowest: compound 1; then compound 3; then compound 2.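

Among the compounds shown here, in the Mus musculus assay compound 2 gives 100% and compound 3 gives 57%, and the change on the saturated chain carbon bound to an amine nitrogen and a saturated chain carbon gives a number 43 percentage points lower from compound 2 to compound 3 (beyond the scatter) as the first step at this place that can be read in one place alone. In a physicochemical assay for solubility, at pH 1.1 (a higher number here means a more soluble compound, a lower number a less soluble compound), compound 2 gives 3000000 nM and compound 3 gives 3000000 nM, and the same change gives no change at the digits printed from compound 2 to compound 3 (within the scatter) and so separates the two compounds in only one read-out. Nothing measured here bears on the reason for this fall. The compounds shown leave open whether the chlorine or the fluorine carries the step, and how a plain phenyl or a pyridine ring would read at this place.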